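The compounds below may be only part of what the source reports. "The series", "measured", "known", "first", "only" and "open" are said of these compounds alone.

Compound 1 `O=C(CSc1nc(Cc2c(F)cccc2F)cc(=O)[nH]1)c1ccccc1`, compound 2 `O=C(CSc1nc(Cc2c(F)cccc2Cl)cc(=O)[nH]1)c1ccccc1` and compound 3 `Cc1c(Cc2c(F)cccc2Cl)nc(SCC(=O)c2ccccc2)[nH]c1=O` were tested in an ADME assay on MT4 cells (Homo sapiens) for cytotoxicity, read by MTT assay; a lower number here means that less compound is tolerated, a higher number that more compound is tolerated. In this assay compound 1 gives > 67000 nM, which is a limit of the assay and not a number. Compound 2 likewise gives only a limit, > 13000 nM. Compound 3 also stops at a limit, > 12000 nM. The step that the two limits leave unreadable from compound 2 to compound 1 and the step that the two limits leave unreadable from compound 2 to compound 3 therefore cannot be sized; the three values show only that none of these compounds reached a measurable half-maximal cytotoxic concentration.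

Compound 4 `Cc1c(Cc2c(F)cccc2F)nc(SCC(=O)c2ccccc2)[nH]c1=O` has not yet been measured in this assay. It differs from compound 3 by fluoro in place of chloro on an aromatic carbon, which is the same change as fluoro in place of chloro on an aromatic carbon, at a place described in the same words. The two cores differ by methyl in place of hydrogen on an aromatic carbon. Every measured value is a limit. The earlier step offers no size to carry over. Compound 4 is expected to remain at a limit as well, with an estimated step that the limit leaves unreadable from compound 3 to compound 4. Compound 4 is thus estimated at 70000 nM, between 20000 nM and 200000 nM.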

Compound 4, half-maximal cytotoxic concentration: 65000 nM
Estimate against measurement, compound 4: 1.1-fold (0.03 log units) above; the measured number falls inside the stated range.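

In this assay, among these compounds, the only step that can be read is the one for methyl in place of hydrogen on an aromatic carbon, an at least 1.0-fold lower number from compound 1 to compound 4 (0.01 log units; that floor lies within the scatter), and it gives only a floor, not a size. The other steps cannot be read, neither fluoro in place of chloro on either core nor methyl in place of hydrogen from compound 2 to compound 3, and compound 3 itself stands at a limit: the limit of > 12000 nM in this assay, at which 1 of the 4 values shown sits. The results therefore show no readable size for either change, and they do not show whether fluoro in place of chloro, or methyl in place of hydrogen, has the same size on both cores.

The compounds shown leave open how this assay responds to other groups in place of the 2-chloro-6-fluorobenzyl or 2,6-difluorobenzyl group, such as an amine, a carboxylic acid or a longer chain. They also leave open where compound 2 and compound 3 would stand if their values were numbers rather than limits.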